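A few compounds are considered here, and "the series" means these few. Any claim that something is new, unique, unknown or untested is made for them only; others in the source may bear on it.

In a functional assay on HepG2 cells (Homo sapiens) for antiproliferative activity, read by sulforhodamine B assay, with a stated time of 72 h (a lower number here means a stronger inhibitor, a higher number a weaker inhibitor), compound 1 (`CC(C)[C@@H](NC(=O)OC(C)(C)C)C(=O)Nc1ccc2ncnc(Nc3cccc(Br)c3)c2c1`) gives > 50000 nM as a limit of the assay and not a number. Compound 2 (`CC(C)C[C@@H](NC(=O)OC(C)(C)C)C(=O)Nc1ccc2ncnc(Nc3cccc(C(F)(F)F)c3)c2c1`) gives > 50000 nM as a limit too, and no numeric value is available for it. For the measured compounds named here, the series so far amounts to the limit of > 50000 nM in this assay, at which 2 of the 2 values shown sit, and offers no number to work from. Compound 3 (`CC(C)C[C@@H](NC(=O)OC(C)(C)C)C(=O)Nc1ccc2ncnc(Nc3cccc(Br)c3)c2c1`) has yet to be measured. Relative to compound 2 the change is bromo in place of trifluoromethyl on an aromatic carbon with bromo in place of trifluoromethyl on an aromatic carbon, meta to a large group. No measured step sizes this change, so no shift beyond the usual scatter is expected, in either direction. The estimated step is a number no higher from compound 2 to compound 3 (the limit leaves the size open) and it rests only on compound 2 at > 50000 nM as a limit. In this assay compound 3 is expected at 50000 nM with an estimated range of 20000 nM to 100000 nM and a reading at the limit is the likeliest outcome.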

Compound 3, half-maximal inhibitory concentration: 25000 nM
Compound 3: the middle estimate sits 2.0-fold (0.30 log units) above what was measured; the range from low to high includes it.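

In this assay, for the compounds shown here, compound 3 gives 25000 nM, the first reading that is a number and not a limit: the limit of > 50000 nM in this assay, at which 2 of the 3 values shown sit. Bromo in place of trifluoromethyl gives an at least 2.0-fold lower number from compound 2 to compound 3 (0.30 log units; that floor lies within the scatter), and isobutyl in place of isopropyl gives an at least 2.0-fold lower number from compound 1 to compound 3 (0.30 log units; that floor lies within the scatter). Both steps are floors set by limits, so the numeric reading shows that this pairing of bromo and isobutyl can be read in this assay, but the true size of either change stays open and neither is shown to go beyond the scatter.

Still open, from the compounds shown here alone, is how far the reading would move with chloro or a nitrile on the same aromatic carbon. Also open, going by these compounds, is what a free amine in place of the carbamate would do to it.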